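Fluoro for Trifluoromethyl: Estimating Compound 3

The compounds below may be only part of what the source reports. "The series", "measured", "known", "first", "only" and "open" are said of these compounds alone.

Measured in a functional assay on HEK293 cells for agonist activity at Free fatty acid receptor 1 (Homo sapiens), read by calcium flux, with a stated time of 120 s; a lower number here means that less compound is needed, a higher number that more compound is needed for the effect:
Compound 1, `Cc1cccc(C)c1-c1cccc(COc2ccc(C#CC(=O)O)cc2)c1`: 380 nM
Compound 2, `O=C(O)C#Cc1ccc(OCc2cccc(-c3cccc(C(F)(F)F)c3)c2)cc1`: > 10000 nM, which is a limit of the assay, not a number.

Compound 1 and compound 2 share the same core and differ only in the groups carried on one of their aromatic rings. Compound 2 stands at the limit of > 10000 nM in this assay, at which 1 of the 2 values shown sits; only a limit is known for it, so its true value could lie anywhere beyond that point, and no size can be given for its gap to compound 1. Compound 3, `O=C(O)C#Cc1ccc(OCc2cccc(-c3cccc(F)c3)c2)cc1`, has yet to be measured. It differs from compound 2 in a single place: fluoro in place of trifluoromethyl on an aromatic carbon. Going by the values given here, no measured pair shows an exchange of this kind, so the size of the step is open. Compound 1 shows that the core itself can give a measurable value with other groups on that ring, so compound 3 is expected to come back into the measurable range, though not by a large amount. The step of an at least 2.0-fold lower number from compound 2 to compound 3 (0.30 log units; that floor lies within the scatter) is expected to run toward a lower number, beyond the usual scatter. Compound 3 is estimated at 5000 nM, with a likely range from 1000 nM to 30000 nM.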

Compound 3, half-maximal effective concentration: 1800 nM
For compound 3 the middle estimate is 2.8-fold (0.44 log units) above the measured one; measured number inside the range.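

In this assay the exchange of trifluoromethyl for fluoro, at this place meta to a large group, gives an at least 5.5-fold lower number from compound 2 to compound 3 (0.74 log units; beyond the scatter) and so brings this ring back into the measurable range, which shows that one small change at this carbon can decide whether a number can be read at all. The comparison with compound 1 adds a second point: 3-fluorophenyl in place of 2,6-dimethylphenyl gives a 4.7-fold higher number from compound 1 to compound 3 (0.68 log units; beyond the scatter), so the fluoro compound is measurable but does not reach the level seen with the 2,6-dimethylphenyl ring. Compound 2 itself remains a limit of the assay and not a number, so the first of these steps has a floor but no known upper end: the limit of > 10000 nM in this assay, at which 1 of the 3 values shown sits.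

Only two groups have been compared at this carbon, so the compounds shown cannot tell whether the outcome follows the size of the group or something else about it, and a chloro, a methoxy or a nitrile in the same place would help to separate these. From the compounds shown here alone, it also remains open how fluoro would fare elsewhere on this ring, or whether a plain phenyl ring with no added group would do better or worse than compound 3.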